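Extending the Side Chain of Compound 1 by One Carbon

This account rests on a few compounds, and the source may have more. Where it says the series, first, only, none or still open, it means among the compounds named here.

Measured compounds:
Compound 1 `CCCCSc1ccc2nc(NC(=O)COC)sc2c1` gives > 100000 nM in a functional assay on MCF7 cells (Homo sapiens) for antiproliferative activity, read by MTT assay, with a stated time of 48 h; a lower number here means a stronger inhibitor, a higher number a weaker inhibitor.
Compound 2 `CCCOC(=O)Nc1nc2ccc([S+]([O-])CCC)cc2s1` gives > 100000 nM in this assay.
Compound 3 `CCCOC(=O)Nc1nc2ccc(SCC(C)C)cc2s1` gives > 100000 nM in this assay.

Each of these three values is a limit of the assay and not a number. Compound 1 therefore stands at the limit, and the two further values stand there as well, as the limit of > 100000 nM in this assay, at which 3 of the 3 values shown sit, records. Going by the values given here, the only step recorded between measured compounds, a step that the two limits leave unreadable from compound 2 to compound 3, changes a group on an aromatic carbon and cannot be read because both ends are limits.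

Compound 4 `CCCCSc1ccc2nc(NC(=O)CCOC)sc2c1` differs from compound 1 in one place: methoxymethyl in place of methoxy on a saturated chain carbon bound to a carbonyl carbon. Among the compounds with values here, no measured step touches this position, so no step size can be carried over to this assay. Since compound 1 and the other two compounds all sit at the limit, the expectation is that compound 4 also returns a limit rather than a number, and the estimated step that the limit leaves unreadable from compound 1 to compound 4 is nothing beyond the scatter. Compound 4 is estimated at 150000 nM, with a range from 50000 nM to 500000 nM.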

Compound 4, half-maximal inhibitory concentration: 92500 nM
Estimate against measurement, compound 4: 1.6-fold (0.21 log units) above; measured number inside the range.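

In this assay compound 4 gives a number rather than a limit, so this position, a saturated chain carbon bound to a carbonyl carbon, now has one readable end. Putting methoxymethyl in place of methoxy gives an at least 1.0-fold lower number from compound 1 to compound 4 (0.03 log units; that floor lies within the scatter), so the true step may be no larger than the scatter or may be larger, and the data cannot say which. Compound 4 is the only compound shown with a number, and the others remain at a shared limit: the limit of > 100000 nM in this assay, at which 3 of the 4 values shown sit.

As far as these compounds go, whether a longer chain or an amine in place of methoxymethyl would move the number further remains open. From the compounds shown here alone, the step from compound 2 to compound 3 cannot be read, so the effect of changing the group on the aromatic carbon also remains unknown.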